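A few compounds are considered here, and "the series" means these few. Any claim that something is new, unique, unknown or untested is made for them only; others in the source may bear on it.

For the measured compounds named here, compound 2 `O=C(NCc1ccc(Cl)s1)c1ccc2[nH]c(-c3ccc(Oc4ccccc4Cl)cc3)nc2c1` is the weaker of the two compounds measured so far in an assay on microsomes from liver (strain Wistar) for inhibition of acyl-CoA desaturase 1 (Rattus norvegicus), with stated times of 10 min and 1 h; a lower number here means a stronger inhibitor, a higher number a weaker inhibitor: compound 2 gives 832 nM, whereas compound 1 `O=C(NCc1nccs1)c1ccc2[nH]c(-c3ccc(Oc4ccccc4Cl)cc3)nc2c1` gives 115 nM. Going by the values given here, the only measured step between them, a 7.2-fold higher number from compound 1 to compound 2 (0.86 log units; beyond the scatter), concerns the group attached to the saturated chain carbon bound to the amide-type nitrogen, and that part is left untouched in what follows.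

Compound 3 `O=C(NCc1ccc(Cl)s1)c1ccc2[nH]c(-c3ccc(Oc4ccccc4C(F)(F)F)cc3)nc2c1` keeps the whole of compound 2 except at the phenoxy ring on the far side of the shared core, where the change is trifluoromethyl in place of chloro on an aromatic carbon, placed on an aromatic carbon of a six-membered aromatic ring of carbon only, ortho to a large group. Among the compounds with values here, no measured step touches this position, so nothing in the numbers in hand points in either direction for this change. The expectation is therefore a step of about a 1.0-fold lower number from compound 2 to compound 3 (0.02 log units; within the scatter) in this assay, within the usual scatter. Compound 3 is estimated at 800 nM in this assay, with a range from 250 nM to 2500 nM.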

Compound 3, half-maximal inhibitory concentration: 142 nM
The estimate for compound 3 lay 5.6-fold (0.75 log units) above the measured number, outside the stated range (below it).
By their numbers in this assay, from the lowest: compounds 1 and 3 (each within the scatter of the next); then compound 2.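

In this assay the phenoxy ring on the far side of the shared core turns out to be a position that responds, since trifluoromethyl in place of chloro gives a 5.9-fold lower number from compound 2 to compound 3 (0.77 log units; beyond the scatter) and this step lies beyond the scatter. The earlier compounds shown here varied only the group on the chain carbon bound to the amide-type nitrogen, so they said nothing about this ring; now a change here is seen to shift the number by a clear margin, with the 5-chlorothiophen-2-yl group left as it was. The exchange puts four heavy atoms where one stood, neither group has hydrogen-bond donors or acceptors, and the larger group on this aromatic carbon comes with a stronger inhibitor, although nothing at hand explains the step.

It remains open whether the same exchange would have a similar effect with the 1,3-thiazol-2-yl group on the chain carbon, as that pairing is not among the compounds shown. Other groups at this place, such as methoxy, nitrile or a plain hydrogen, are also absent, so a single step cannot show how far the trend extends.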